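Cytotoxicity of three nucleoside analogues and an expected fourth

The source may report more compounds than this note shows. Statements on the series, on what has been measured and on what is new or still open speak of the compounds shown alone.

Working notes on a small set of nucleosides screened in an ADME assay on MRC5 cells (Homo sapiens), read by MTT assay, with a stated time of 72 h; a higher number here means a weaker inhibitor, a lower number a stronger inhibitor. Compound 1, `Nc1nc2c(c(-c3ccccc3)cn2[C@@H]2O[C@H](CO)[C@@H](O)[C@H]2O)c(=O)[nH]1`, gives > 100000 nM in this assay, which is a limit of the assay and not a number. Compound 2, `O=c1[nH]cnc2c1c(-c1ccsc1)cn2[C@@H]1O[C@H](CO)[C@@H](O)[C@H]1O`, gives > 100000 nM in this assay, again a limit and not a number. Compound 3, `Nc1nc2c(c(-c3ccco3)cn2[C@@H]2O[C@H](CO)[C@@H](O)[C@H]2O)c(=O)[nH]1`, gives > 100000 nM in this assay, also a limit and not a number. Going by the values given here, the one single-point step available, a step that the two limits leave unreadable from compound 1 to compound 3, cannot be read in size because both ends sit at the limit. Compound 3 therefore stands at the same limit as the other two values shown, as summarised by the limit of > 100000 nM in this assay, at which 3 of the 3 values shown sit.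

The next compound is compound 4, `Nc1nc2c(c(-c3ccsc3)cn2[C@@H]2O[C@H](CO)[C@@H](O)[C@H]2O)c(=O)[nH]1`. Its difference from compound 3 is thiophen-3-yl in place of furan-2-yl on an aromatic carbon. Among the compounds with values here, no measured step here compares a thiophen-3-yl against a furan-2-yl, so the step from compound 1 to compound 3 is the only one bearing on it, and it is unreadable. Compound 4 is estimated to sit where the series sits, at the limit, with 200000 nM and a range from 100000 nM to 1000000 nM. The step this expectation implies, a step that the limit leaves unreadable from compound 3 to compound 4, is expected to be no larger than the scatter.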

Compound 4, half-maximal inhibitory concentration: > 100000 nM
Compound 4: no number, only a limit; the forecaster's own chance of this, stated with the estimate: 85%; the middle value does not contradict the limit.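

Compound 4 gives only a limit and not a number, and none of its steps to compound 1, compound 2 and compound 3 can be read in this assay. The compounds shown leave open whether phenyl, furan-2-yl and thiophen-3-yl differ at all in this assay, or whether amino in place of hydrogen matters, with the whole series resting at one point: the limit of > 100000 nM in this assay, at which 4 of the 4 values shown sit.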